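Compound 3 to compound 4: a pyridin-2-yl group enters

The source may hold more compounds than are shown below. What is called first, only, known or untested is meant among the compounds shown, and "the series" means these compounds.

In a functional assay on MCF7 cells (Homo sapiens) for antiproliferative activity, read by CellTiter-Glo, with a stated time of 5 days (on this read-out higher numbers stand for weaker inhibition and lower numbers for stronger inhibition), compound 3 (`O=C(O)/C=C/c1ccc(/C(=C(\c2ccc(C(F)(F)F)cc2Cl)C2CCC2)c2ccc(-c3cn[nH]c3)cc2)cc1`) gives 16 nM within the scatter of compound 2 (`O=C(O)/C=C/c1ccc(/C(=C(\c2ccccc2)C2CCC2)c2ccc(-c3cn[nH]c3)cc2)cc1`) at 11 nM on this read-out. Compound 1 (`O=C(O)/C=C/c1ccc(/C(=C(\c2ncc(C(F)(F)F)cc2Cl)C2CCC2)c2ccc(-c3cncs3)cc2)cc1`) gives 7.3 nM as a lower number than compound 3, and that gap lies beyond the scatter.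

Compound 4 (`O=C(O)/C=C/c1ccc(/C(=C(\c2ncc(C(F)(F)F)cc2Cl)C2CCC2)c2ccc(-c3cn[nH]c3)cc2)cc1`) has 3-chloro-5-(trifluoromethyl)pyridin-2-yl in place of 2-chloro-4-(trifluoromethyl)phenyl on a double-bonded chain carbon bound to a double-bonded chain carbon and a saturated ring carbon and is otherwise the same as compound 3.

For the measured compounds named here, only one measured step touches this carbon: a 1.5-fold higher number from compound 2 to compound 3 (0.16 log units; within the scatter) and it stays within the scatter. This suggests that the series tolerates a change of group there. Going by the values given here, compound 1 already carries the entering group and gives 7.3 nM as the only value with it, but compound 1 differs from compound 4 elsewhere in the structure, so it offers no more than a hint towards a lower number.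

The expected size in this assay is a 1.5-fold lower number from compound 3 to compound 4 (0.16 log units; within the scatter) towards a slightly lower number and not beyond the scatter. In this assay compound 4 is estimated at 11 nM with an expected range from 4.5 nM to 26 nM as its bounds.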

Compound 4, half-maximal inhibitory concentration: 16 nM
Compound 4: the middle estimate sits 1.5-fold (0.16 log units) below what was measured; measured number inside the range.
By their numbers in this assay, from the lowest: compounds 1, 2, 3 and 4 (each within the scatter of the next, the first and the last beyond it).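

In this assay, placing a ring nitrogen in the aryl group on the double-bonded chain carbon gives no change at the digits printed from compound 3 to compound 4 (within the scatter), so with 1H-pyrazol-4-yl held constant, this exchange of 2-chloro-4-(trifluoromethyl)phenyl for 3-chloro-5-(trifluoromethyl)pyridin-2-yl, which adds a hydrogen-bond acceptor to the count, leaves the read-out unmoved. Measured against the bare ring, the same place shows a 1.5-fold higher number from compound 2 to compound 4 (0.16 log units; within the scatter), so phenyl, 2-chloro-4-(trifluoromethyl)phenyl and 3-chloro-5-(trifluoromethyl)pyridin-2-yl now all lie within the scatter of one another in this pyrazole-bearing set. The lower number of compound 1 therefore finds no support from the entering group itself: the one-place comparison is a 2.2-fold higher number from compound 1 to compound 4 (0.34 log units; beyond the scatter), which belongs to the exchange of 1H-pyrazol-4-yl and 1,3-thiazol-5-yl on an aromatic carbon.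

No measurement at hand accounts for either the flat result on the chain carbon or the gap on the aromatic carbon. Still open, from the compounds shown here alone, is whether this tolerance extends to an amine or a carboxylic acid on the aryl group at the double-bonded chain carbon, and whether 1,3-thiazol-5-yl keeps its step when paired with phenyl or 2-chloro-4-(trifluoromethyl)phenyl.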